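Para substituent swap on the shared core

The source may report more compounds than this note shows. Statements on the series, on what has been measured and on what is new or still open speak of the compounds shown alone.

Measured compounds:
compound 1 `CN1CCC[C@@H]1Cn1nc(Cc2ccc(O)cc2)c2ccccc2c1=O` — 398 nM
compound 2 `CN1CCC[C@@H]1Cn1nc(Cc2ccc(F)c(F)c2)c2ccccc2c1=O` — 316 nM

In an assay for binding affinity to Alpha-1B adrenergic receptor (Homo sapiens) (a lower number here means a stronger inhibitor, a higher number a weaker inhibitor), compound 1 gives 398 nM. Compound 2, in this assay, gives 316 nM. Among the measured compounds shown here, the single measured step, a 1.3-fold lower number from compound 1 to compound 2 (0.10 log units; within the scatter), is within the scatter, so compound 1 and compound 2 cannot be ranked against each other on these numbers; compound 1 simply sits alongside compound 2.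

Compound 3 `COC(=O)c1ccc(Cc2nn(C[C@H]3CCCN3C)c(=O)c3ccccc23)cc1` is not yet measured in this assay. It differs from compound 1 by methoxycarbonyl in place of hydroxy on an aromatic carbon. For the measured compounds named here, the only measured step that bears on this change is the one from compound 1 to compound 2, where a different aryl substituent pattern on the same pendant ring moved the number by a 1.3-fold lower number from compound 1 to compound 2 (0.10 log units; within the scatter), which is within the scatter. That step touches the same pendant ring but replaces hydroxy with a different kind of group than methoxycarbonyl, so it guides the expectation only loosely. On the evidence shown, no step beyond the scatter is expected in this assay.

Compound 3 is therefore expected to give about 400 nM in this assay, with a range of 150 nM to 1100 nM, an estimated step of a 1.0-fold higher number from compound 1 to compound 3 (0.00 log units; within the scatter).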

Compound 3, inhibition constant: > 1990 nM
Compound 3: only a limit was reported (the forecaster's own chance of this, stated with the estimate: 5%); middle value at least 4.9-fold (0.69 log units) away from the limit.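

In this assay, among the compounds shown here, methoxycarbonyl in place of hydroxy on the aromatic carbon para to a large group gives an at least 5.0-fold higher number from compound 1 to compound 3 (0.69 log units; beyond the scatter), the first step beyond the scatter, so the number does respond to what stands at this position. The earlier step, a 1.3-fold lower number from compound 1 to compound 2 (0.10 log units; within the scatter), did not show this; it also removes the hydroxy yet stays within the scatter, so losing the hydroxy alone does not account for the new step, and the step goes with the methoxycarbonyl that enters. The reading for compound 3 is a limit of the assay, not a number: the limit of > 1990 nM in this assay, at which 1 of the 3 values shown sits.

From the compounds shown here alone, how large the step really is stays open, and so does which part of the methoxycarbonyl goes with it. A carboxylic acid, a primary amide or a methyl on the same aromatic carbon would help to separate the carbonyl, the ester methyl and the overall count of 4 heavy atoms as candidates.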